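Aryl swap on the core of compound 1

The source may report more compounds than this note shows. Statements on the series, on what has been measured and on what is new or still open speak of the compounds shown alone.

Measured in an in vitro functional assay on HEK285-7 cells for antagonist activity at prostaglandin D2 receptor 2 (Homo sapiens), read by BRET and beta-arrestin recruitment (a higher number here means a weaker inhibitor, a lower number a stronger inhibitor), so far:
Compound 1, `COc1cc(-c2nc(C(c3ccc(F)cc3)c3ccc(F)cc3)sc2CC(=O)O)ccn1` — compound 1 gives 380 nM.
Compound 2, `COc1ccc(OC)c(-c2nc(C(c3ccccc3)c3ccccc3)sc2CC(=O)O)c1` — compound 2 reaches only a limit of the assay, > 100000 nM.
Compound 3, `O=C(O)Cc1sc(C2COc3ccccc3O2)nc1-c1ccc(Cl)cc1` — compound 3 gives 2000 nM.

Compound 1 holds the lowest of the two numbers shown in this assay; the nearest is compound 3, whose number is higher by a gap that is beyond the scatter. Compound 2 sits at the limit of the assay (the limit of > 100000 nM in this assay, at which 1 of the 3 values shown sits), so it contributes no number to compare against.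

The compound awaiting measurement is compound 4, `N#Cc1ccc(-c2nc(C(c3ccc(F)cc3)c3ccc(F)cc3)sc2CC(=O)O)cc1`. Relative to compound 1, the change is 4-cyanophenyl in place of 2-methoxypyridin-4-yl on an aromatic carbon. Among the compounds with values here, no pair of measured compounds differs in one place, so there is no measured step of this kind to lean on, and the two aryl groups on the core of compound 1 and compound 3 are not comparable in a single step either.

The expectation is therefore anchored on compound 1 alone. A step of modest size, toward a slightly higher number, is expected, but not one that would clearly clear the scatter; the expected step is a 1.4-fold higher number from compound 1 to compound 4 (0.16 log units; within the scatter) in this assay. For compound 4 the estimated value in this assay is 550 nM, with a range from 150 nM to 2500 nM.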

Compound 4, half-maximal inhibitory concentration: 1500 nM
Compound 4: the middle estimate sits 2.7-fold (0.44 log units) below what was measured, and the stated range covers the measured number.
By their numbers in this assay, from the lowest: compound 1; then compounds 4 and 3 (each within the scatter of the next). At a limit, above all of these: compound 2.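

With the rest of compound 1 held constant, the aromatic carbon next to the ring nitrogen proves sensitive to the aryl group it carries: replacing 2-methoxypyridin-4-yl with 4-cyanophenyl gives a 3.9-fold higher number from compound 1 to compound 4 (0.60 log units; beyond the scatter) in this assay. The two groups match in heavy-atom count and each is a single six-membered aromatic ring, so this step appears without any change in those counted features, although the hetero atom in the ring and the methoxy oxygen both leave and a triple bond enters. Within the data shown here, the position still accepts the new aryl group, with compound 4 giving a measured 1500 nM rather than a limit of the assay, but nothing measured so far accounts for the size of the step.

This single step cannot separate the contribution of the ring nitrogen of the 2-methoxypyridin-4-yl group from that of the exchange of methoxy for nitrile, as both change together. Also open, on these data alone, is how this position responds to a primary amide or an amine in place of the nitrile on the same phenyl ring, with the rest of the core of compound 1 unchanged.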